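This account rests on a few compounds, and the source may have more. Where it says the series, first, only, none or still open, it means among the compounds named here.

In an ADME assay on microsomes from liver (Mus musculus) for metabolic stability (on this read-out lower numbers stand for slow clearance and higher numbers for fast clearance), compound 1 (`Cc1ccc(S(=O)(=O)Nc2ccc(CN(C)[C@@H]3CCN(C(=O)c4cccc(Cl)c4)C3)cc2)cc1`) gives > 50 mL.min-1.g-1 as a limit of the assay and not a number. Compound 2 (`Cc1ccc(S(=O)(=O)Nc2ccc(CN(C)[C@H]3CCN(C(=O)c4cccc(Cl)c4)C3)cc2)cc1`) likewise gives > 50 mL.min-1.g-1 as a limit. The pair offers a step that the two limits leave unreadable from compound 1 to compound 2 and nothing more, with the fact that compounds 1 and 2 differ only in the configuration as drawn as all that separates them. Compound 1 therefore stands at the limit of > 50 mL.min-1.g-1 in this assay, at which 2 of the 3 values shown sit, and gives no number to start from. Differing from compound 1 in more than one place, compound 3 (`COc1ccc(S(=O)(=O)Nc2ccc(OC3CCN(C(=O)c4cccc(Cl)c4)CC3)cc2)cc1`) gives 37 mL.min-1.g-1 as the only true number here.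

The step to compound 4 (`Cc1ccc(S(=O)(=O)Nc2ccc(CN[C@@H]3CCN(C(=O)c4cccc(Cl)c4)C3)cc2)cc1`) is hydrogen in place of methyl on an amine nitrogen. For the measured compounds named here, no measured step touches that nitrogen, so none gives a size for this change. Going by the values given here, with compound 1 at > 50 mL.min-1.g-1 as a limit, clearance is expected to remain fast in this assay with no step clearly beyond the scatter. The expected change is an at least 1.1-fold lower number from compound 1 to compound 4 (0.04 log units; that floor lies within the scatter) as estimated here. For compound 4 the estimate is 45 mL.min-1.g-1 with an expected range from 20 mL.min-1.g-1 to 75 mL.min-1.g-1 overall.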

Compound 4, intrinsic clearance in microsomes in the Mus musculus assay: 48 mL.min-1.g-1
Compound 4: the middle estimate sits 1.1-fold (0.03 log units) below what was measured; low and high end bracket the measured number.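

In the Mus musculus assay the change from methyl to hydrogen on this amine nitrogen gives an at least 1.0-fold lower number from compound 1 to compound 4 (0.01 log units; that floor lies within the scatter), so nothing shows that clearance moved. Compound 4 gives a true number where compound 1 gives only a limit of the assay, so this step has a floor and no full size. In a physicochemical assay for solubility, measured as kinetic solubility (on this read-out higher numbers stand for higher solubility and lower numbers for lower solubility), compound 1 gives 28000 nM and compound 4 gives 75000 nM. In the physicochemical assay the same change gives a reading that the pair of compounds 1 and 2 did not offer, and here the step is clear: the measured solubility of compound 1, 28000 nM, and of compound 4, 75000 nM, a 2.7-fold higher number (0.43 log units; beyond the scatter)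

The compounds shown leave open how an ethyl group or an acetyl group on that amine nitrogen would behave in the Mus musculus assay and in the physicochemical assay. They also leave open whether hydrogen in place of methyl would give a step of similar size in compound 2, whose stereocentre is drawn the other way.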